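Aryl amine variation in an antiproliferative thiourea sulfonamide series

A few compounds are considered here, and "the series" means these few. Any claim that something is new, unique, unknown or untested is made for them only; others in the source may bear on it.

Measured so far:
compound 1 `NS(=O)(=O)c1ccc(NC(=S)Nc2ccc3ncnc(Nc4ccc(Cl)c(C(F)(F)F)c4)c3c2)cc1`: 18200 nM
compound 2 `Cc1cccc(Nc2ncnc3ccc(NC(=S)Nc4ccc(S(N)(=O)=O)cc4)cc23)c1`: 23800 nM

In a functional assay on A-431 cells (Homo sapiens) for antiproliferative activity, read by MTT assay, with a stated time of 72 h (on this read-out higher numbers stand for weaker inhibition and lower numbers for stronger inhibition), compound 1 gives 18200 nM and compound 2 gives 23800 nM. Going by the values given here, the only single-point step between measured compounds is a 1.3-fold higher number from compound 1 to compound 2 (0.12 log units; within the scatter), which swaps one aryl group on the nitrogen on the aromatic ring for another. Compound 2 thus stands within the scatter of compound 1, and on these two numbers alone no ordering between them can be read.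

Compound 3 `CCc1ccc(Nc2ncnc3ccc(NC(=S)Nc4ccc(S(N)(=O)=O)cc4)cc23)cc1` is not yet measured. It differs from compound 2 by 4-ethylphenyl in place of 3-methylphenyl on a nitrogen on an aromatic ring. Among the compounds with values here, the one step that bears on this change is a 1.3-fold higher number from compound 1 to compound 2 (0.12 log units; within the scatter), where a different aryl group at the same place left the number within the scatter. Two aryl groups of quite different make-up gave the same read-out, so a third aryl group at this position is expected to do likewise; no step beyond the scatter is expected in this assay, in either direction. The step from compound 2 to compound 3 is estimated as a 1.1-fold lower number from compound 2 to compound 3 (0.03 log units; within the scatter). Compound 3 is therefore estimated at 22000 nM, with a range from 9000 nM to 55000 nM.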

Compound 3, half-maximal inhibitory concentration: 38400 nM
The estimate for compound 3 lay 1.7-fold (0.24 log units) below the measured number; the measured number falls inside the stated range.
By their numbers in this assay, from the lowest: compounds 1, 2 and 3 (each within the scatter of the next, the first and the last beyond it).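

In this assay the change from 3-methylphenyl to 4-ethylphenyl on the nitrogen on an aromatic ring stays within the scatter (a 1.6-fold higher number from compound 2 to compound 3 (0.21 log units; within the scatter)), so these two aryl groups cannot be ordered. Going by these compounds alone, the same position now gives the first step beyond the scatter, a modest one (a 2.1-fold higher number from compound 1 to compound 3 (0.32 log units; beyond the scatter)): 4-ethylphenyl reads as weaker than 4-chloro-3-(trifluoromethyl)phenyl, a separation that 3-methylphenyl did not show against that same group. Across these three aryl groups the position therefore shows only a small spread, and no measurement available here bears on what lies behind it.

Still open, as far as these compounds go, is whether a longer chain in place of the ethyl, or an amine or a carboxylic acid on the phenyl ring, would carry the number beyond the scatter of compound 2 or compound 3. Also open, from the compounds shown here alone, is whether a small alkyl group and a halogen-bearing group would separate in the same way on other aryl groups at this position, as three compounds cannot settle that.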